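Fluorine on the shared core of two bisindolyl oxindoles

The source may hold more compounds than are shown below. What is called first, only, known or untested is meant among the compounds shown, and "the series" means these compounds.

Compound 1, `COc1ccc2c(C3(c4c[nH]c5cc(OC)ccc45)C(=O)Nc4ccccc43)c[nH]c2c1`, in a functional assay on SK-N-SH cells (Homo sapiens) for cytotoxicity, read by MTT assay, with a stated time of 48 h (on this read-out lower numbers stand for stronger inhibition and higher numbers for weaker inhibition), gives 13600 nM.
Compound 2, `O=C1Nc2ccccc2C1(c1c[nH]c2ccc(Br)cc12)c1c[nH]c2ccc(Br)cc12`, in this assay gives 13200 nM.
Compound 3, `COc1ccc2c(C3(c4c[nH]c5cc(OC)ccc45)C(=O)Nc4ccc(F)cc43)c[nH]c2c1`, in this assay gives 4100 nM.

Compound 1 and compound 3 share a core and differ in one place: fluoro in place of hydrogen on an aromatic carbon. This change made a step of a 3.3-fold lower number from compound 1 to compound 3 (0.52 log units; beyond the scatter). Compound 2 carries a different core; the difference between the two cores is not broken down here, and what is seen is that compound 2 and compound 1 give values within the usual scatter of each other.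

Compound 4, `O=C1Nc2ccc(F)cc2C1(c1c[nH]c2ccc(Br)cc12)c1c[nH]c2ccc(Br)cc12`, has not yet been measured. It differs from compound 2 in the same way that compound 3 differs from compound 1: fluoro in place of hydrogen on an aromatic carbon. The place of the change is the same in both pairs. The same change occurs twice among the compounds shown, and only once with a measured outcome.

The expectation for compound 4 therefore rests on one measured step. Because compound 1 to compound 3 moved by a 3.3-fold lower number from compound 1 to compound 3 (0.52 log units; beyond the scatter), and because compound 2 starts from 13200 nM, a step of similar size is expected from compound 2 to compound 4, namely a 2.9-fold lower number from compound 2 to compound 4 (0.47 log units; beyond the scatter). On this basis compound 4 is estimated to give 4500 nM in this assay, with a range from 2000 nM to 12000 nM reflecting that a single precedent leaves the size of the step uncertain.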

Compound 4, half-maximal inhibitory concentration: 2800 nM
Compound 4: middle estimate off by 1.6-fold (0.21 log units), on the high side; low and high end bracket the measured number.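

Fluoro in place of hydrogen on an aromatic carbon made a step of a 4.7-fold lower number from compound 2 to compound 4 (0.67 log units; beyond the scatter) in this assay, in the same direction as the earlier step of a 3.3-fold lower number from compound 1 to compound 3 (0.52 log units; beyond the scatter). Set side by side, the two steps do not differ in size: the same change on two cores in this assay, a 3.3-fold lower number (0.52 log units; beyond the scatter) from compound 1 to compound 3 and a 4.7-fold lower number (0.67 log units; beyond the scatter) from compound 2 to compound 4, 1.4-fold (0.15 log units) apart, within the scatter of two such steps Within this series, then, the change carried over from the core of compound 1 to the core of compound 2 with a similar outcome, but two pairs, with the change at one place and read in one assay, do not make a rule for other cores and do not show why the number falls.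

The compounds shown leave open whether another group at the same place, such as chloro, methoxy or a nitrile, would move the number as fluoro does, and whether fluoro elsewhere on the six-membered aromatic ring would do the same. They also leave open whether the step would hold on a core that carries neither the methoxy groups of compound 1 nor the bromo groups of compound 2.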